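The source may hold more compounds than are shown below. What is called first, only, known or untested is meant among the compounds shown, and "the series" means these compounds.

Series measured in a functional assay on HepG2 cells (Homo sapiens) for cytotoxicity, read by MTT assay, with a stated time of 24 h; a higher number here means a weaker inhibitor, a lower number a stronger inhibitor:
- compound 1 `O=C1/C(=C/c2cccnc2)CN(S(=O)(=O)c2ccccc2)C/C1=C\c1ccccc1C(F)(F)F`: 5370 nM
- compound 2 `Cc1ccc(S(=O)(=O)N2C/C(=C\c3cccnc3)C(=O)/C(=C/c3ccccc3C(F)(F)F)C2)cc1`: 2930 nM
- compound 3 `O=C1/C(=C/c2cccnc2)CN(S(=O)(=O)c2ccc(F)cc2)C/C1=C\c1ccccc1C(F)(F)F`: 2340 nM

Compound 3 sits at the low end of these numbers, but it is clearly separated on one side only. The gap on that side is a 2.3-fold lower number from compound 1 to compound 3 (0.36 log units; beyond the scatter), while the gap on the other is a 1.3-fold lower number from compound 2 to compound 3 (0.10 log units; within the scatter).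

The next change gives compound 4 `O=C1/C(=C/c2cccnc2)CN(S(=O)(=O)c2ccc(Br)cc2)C/C1=C\c1ccccc1C(F)(F)F`: bromo in place of fluoro on an aromatic carbon. This is bromo in place of fluoro on an aromatic carbon, para to a large group.

Three measured steps at that same carbon bear on it. Hydrogen to methyl is a 1.8-fold lower number from compound 1 to compound 2 (0.26 log units; within the scatter). Hydrogen to fluoro is a 2.3-fold lower number from compound 1 to compound 3 (0.36 log units; beyond the scatter). Methyl to fluoro is a 1.3-fold lower number from compound 2 to compound 3 (0.10 log units; within the scatter). Among the compounds with values here, all three are small, and only the step from hydrogen to fluoro exceeds the scatter, modestly. Within the data shown here, no measured compound carries bromo, so this expectation rests on the small size of those steps alone. No step beyond the scatter is expected in this assay, and the direction is left open. The expected step is a 1.1-fold lower number from compound 3 to compound 4 (0.03 log units; within the scatter). For compound 4 the estimated value is 2200 nM, with an expected range of 1100 nM to 4400 nM.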

Compound 4, half-maximal inhibitory concentration: 2730 nM
Compound 4: middle estimate off by 1.2-fold (0.09 log units), on the low side, within the range that was stated.
By their numbers in this assay, from the lowest: compounds 3, 4, 2 and 1 (each within the scatter of the next, the first and the last beyond it).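

In this assay, the change at this carbon, para to a large group, now covers a second halogen, and bromo in place of fluoro gives a 1.2-fold higher number from compound 3 to compound 4 (0.07 log units; within the scatter) without separating the two halogens. Bromo in place of methyl gives a 1.1-fold lower number from compound 2 to compound 4 (0.03 log units; within the scatter) and likewise shows no separation, so the 4-bromophenyl, 4-fluorophenyl and methyl-bearing sulfonyl compounds cannot be ordered among themselves on these numbers. Bromo in place of hydrogen gives a 2.0-fold lower number from compound 1 to compound 4 (0.29 log units; within the scatter), which remains inside the scatter even though fluoro in place of hydrogen gives a 2.3-fold lower number from compound 1 to compound 3 (0.36 log units; beyond the scatter) and lies modestly beyond it, so that single step beyond the scatter does not extend to a general halogen pattern, and no information is available to explain these results.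

All substituents shown at this carbon are small and uncharged, so it remains open whether an amine, a carboxylic acid or a longer chain there would produce a clearer step in this assay than any seen so far. From the compounds shown here alone, the trifluoromethyl-bearing ring and the pyridine-bearing side stay the same throughout these compounds, so what changes at those places would do also remains open.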